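The compounds below may be only part of what the source reports. "The series", "measured", "known", "first", "only" and "open" are said of these compounds alone.

Compound 1 `COc1cc2c(Oc3ccc(NC(=O)c4cn(-c5ccc(Cl)cc5)cn4)cc3F)ccnc2cc1OCCCN1CCN(C)CC1`: 1350 nM
Compound 2 `COc1cc2c(Oc3ccc(NC(=O)c4cn(-c5ccccc5OC(F)(F)F)cn4)cc3F)ccnc2cc1OCCCN1CCCCC1`: 250 nM
Compound 3 `COc1cc2c(Oc3ccc(NC(=O)c4cn(-c5cc(C)ccc5C)cn4)cc3F)ccnc2cc1OCCCN1CCCCC1`: 580 nM

Of the compounds shown here, three built on the shared core have been measured in a functional assay on HT-29 cells (Homo sapiens) for cytotoxicity, read by MTT assay, with a stated time of 72 h; on this read-out higher numbers stand for weaker inhibition and lower numbers for stronger inhibition. Compound 1 gives 1350 nM, compound 2 gives 250 nM and compound 3 gives 580 nM. Compound 3 therefore holds the second highest of the three numbers; its nearest neighbour is compound 2, and compound 1 lies furthest from it. Within the data shown here, the single step recorded between these compounds, a 2.3-fold higher number from compound 2 to compound 3 (0.37 log units; beyond the scatter), came with an exchange of the group on the aromatic nitrogen.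

Compound 4 `COc1cc2c(Oc3ccc(NC(=O)c4cn(-c5ccc(Cl)cc5)cn4)cc3F)ccnc2cc1OCCCN1CCCCC1` has not yet been measured. It differs from compound 3 by 4-chlorophenyl in place of 2,5-dimethylphenyl on an aromatic nitrogen. Among the measured compounds shown here, the step from compound 2 to compound 3 is the only measured change at this position, and it was modest in size. Compound 1 carries the same 4-chlorophenyl group as compound 4 but a different tail, so its value can serve only as a hint, not as a step. The expected outcome is therefore a modest rise in the number in this assay, a 1.5-fold higher number from compound 3 to compound 4 (0.17 log units; within the scatter), in the direction where compound 1 stands. Compound 4 is estimated to give 850 nM, with a range from 300 nM to 2500 nM.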

Compound 4, half-maximal inhibitory concentration: 2780 nM
Estimate against measurement, compound 4: 3.3-fold (0.51 log units) below; measured number above the stated range.
By their numbers in this assay, from the lowest: compound 2; then compound 3; then compound 1; then compound 4.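

Among these compounds, with the piperidin-1-yl tail held constant, the group on the aromatic nitrogen proves able to move the result in this assay much further than the earlier compounds showed: 4-chlorophenyl in place of 2,5-dimethylphenyl gives a 4.8-fold higher number from compound 3 to compound 4 (0.68 log units; beyond the scatter), and 4-chlorophenyl in place of 2-(trifluoromethoxy)phenyl gives an 11-fold higher number from compound 2 to compound 4 (1.05 log units; beyond the scatter). Of the three groups compared at this position with this tail, 4-chlorophenyl therefore carries the highest number, and the change from 2-(trifluoromethoxy)phenyl is large rather than modest. The tail also counts, since with 4-chlorophenyl held constant, piperidin-1-yl in place of 4-methylpiperazin-1-yl gives a 2.1-fold higher number from compound 1 to compound 4 (0.31 log units; beyond the scatter), so the tail exchange does not lower the number for this pair.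

As far as these compounds go, it remains open whether the rise belongs to the chlorine itself or to where it sits, a question that an unsubstituted phenyl or a 2-chlorophenyl group on the same nitrogen would address, and whether the tail step holds with 2-(trifluoromethoxy)phenyl as well. Nothing available here accounts for the size of any of these differences.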